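The source may hold more compounds than are shown below. What is called first, only, known or untested is meant among the compounds shown, and "the series" means these compounds.

In a functional assay on L1210 cells (Mus musculus) for inhibition (a higher number here means a weaker inhibitor, a lower number a stronger inhibitor), three compounds have been measured:

compound 1 `O=C1/C(=C/c2ccc(F)cc2)Cc2ccccc21`, 89000 nM
compound 2 `O=C1/C(=C/c2ccc(Cl)cc2)Cc2ccccc21`, 54100 nM
compound 3 `O=C1/C(=C/c2ccc(F)cc2)CCCc2ccccc21`, 60300 nM

Compound 1 and compound 2 share one core and differ only by chloro in place of fluoro on an aromatic carbon. That change gave a 1.6-fold lower number from compound 1 to compound 2 (0.22 log units; within the scatter). Compound 3 carries the same fluoro group on a different core; the difference between the two cores is not broken down here. The numbers for compound 3 and compound 2 lie within the scatter of each other, as do those for compound 3 and compound 1, so the three measured compounds are not separated by this assay.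

Compound 4 `O=C1/C(=C/c2ccc(Cl)cc2)CCCc2ccccc21` has not yet been measured. It differs from compound 3 by chloro in place of fluoro on an aromatic carbon, the same change that turns compound 1 into compound 2, made on the core of compound 3. Within the data shown here, the only guide to its size is the single earlier step, which stayed within the scatter. Compound 4 is therefore expected to show a 1.5-fold lower number from compound 3 to compound 4 (0.18 log units; within the scatter), a step resting on a 1.6-fold lower number from compound 1 to compound 2 (0.22 log units; within the scatter). In this assay compound 4 is estimated at 40000 nM, with a likely range from 20000 nM to 90000 nM.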

Compound 4, half-maximal inhibitory concentration: 51800 nM
Beside the measured number, compound 4's estimate is 1.3-fold (0.11 log units) below it; low and high end bracket the measured number.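

Chloro in place of fluoro on an aromatic carbon, carried onto the core of compound 3, gave in this assay a 1.2-fold lower number from compound 3 to compound 4 (0.07 log units; within the scatter). Set beside the same change on the core of compound 1, this step does not differ from the earlier one: the same change on two cores in this assay, a 1.6-fold lower number (0.22 log units; within the scatter) from compound 1 to compound 2 and a 1.2-fold lower number (0.07 log units; within the scatter) from compound 3 to compound 4, 1.4-fold (0.15 log units) apart, within the scatter of two such steps. The change therefore reads alike on the two cores, but this is agreement between two small steps that each stay within the scatter, so it does not show that chloro and fluoro truly differ on either core, nor that a real effect of the change carries from one core to the other.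

The compounds shown hold only fluoro and chloro at this place, on two cores, and all four numbers stay close together, so it remains open whether a larger departure such as a methoxy group, an amine or a carboxylic acid on the same aromatic carbon would give a step beyond the scatter in this assay. Whether any step would hold on a third core is also left open.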